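A Methyl Added Where Every Value Is a Limit

A few compounds are considered here, and "the series" means these few. Any claim that something is new, unique, unknown or untested is made for them only; others in the source may bear on it.

The study reads an ADME assay on HUVEC cells (Homo sapiens) for antiproliferative activity, read by MTT assay, with a stated time of 48 h; on this read-out higher numbers stand for weaker inhibition and lower numbers for stronger inhibition. Compound 1 `N#CC1=C(N)Oc2c(c3nc4ccccc4nc3c3ccccc23)C12C(=O)N(Cc1cnnn1-c1ccc(Br)cc1)c1ccccc12` reaches only the limit of this assay, giving > 50000 nM. Compound 2 `Cc1ccc(Cl)cc1-n1nncc1CN1C(=O)C2(C(C#N)=C(N)Oc3c2c2nc4ccccc4nc2c2ccccc32)c2ccccc21` likewise reaches only the limit, giving > 50000 nM. The step that the two limits leave unreadable from compound 1 to compound 2 is therefore unreadable, since both ends are limits. Compound 3 `Cc1cccc(-n2nncc2CN2C(=O)C3(C(C#N)=C(N)Oc4c(N)cc5nc6ccccc6nc5c43)c3ccccc32)c1` also stands at a limit in this assay, giving > 50000 nM, and so it stands where every value in this set stands, at the limit of > 50000 nM in this assay, at which 3 of the 3 values shown sit.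

Compound 4 `Cc1cc(C)cc(-n2nncc2CN2C(=O)C3(C(C#N)=C(N)Oc4c(N)cc5nc6ccccc6nc5c43)c3ccccc32)c1` differs from compound 3 in one place: methyl in place of hydrogen on an aromatic carbon. For the measured compounds named here, no measured step in this set carries a readable size, and the only step between compounds differing in one place, a step that the two limits leave unreadable from compound 1 to compound 2, lies between two limits, so nothing here gives this methyl a direction or a size. Compound 4 is therefore expected to show a step that the limit leaves unreadable from compound 3 to compound 4, no movement beyond the scatter, and its value in this assay is estimated at 60000 nM, within 20000 nM to 200000 nM, most probably reported again only as a limit.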

Compound 4, half-maximal inhibitory concentration: > 50000 nM
Compound 4: a limit, no number; the forecaster's own chance of this, stated with the estimate: 85%; the middle value is on the limit's open side.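

In this assay compound 4 gives > 50000 nM, which is a limit. For the compounds shown here, compound 3 stands at a limit too, so no step from compound 3 to compound 4 can be read. The compounds shown leave open whether this methyl has any effect, and of what size and direction: the limit of > 50000 nM in this assay, at which 4 of the 4 values shown sit.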